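Ethoxycarbonyl in Place of Trifluoromethoxy: Expectation for Compound 4

A few compounds are considered here, and "the series" means these few. Any claim that something is new, unique, unknown or untested is made for them only; others in the source may bear on it.

Compound 1, `O=C1C(Nc2ccc(OC(F)(F)F)cc2)=CC(=O)c2ncncc21`, 900 nM
Compound 2, `CCc1ccc(-c2ccc(NC3=CC(=O)c4ncncc4C3=O)cc2)cc1`, 3100 nM
Compound 3, `COc1cc(NC2=CC(=O)c3ncncc3C2=O)cc(OC)c1OC`, 1600 nM

In a functional assay on BXPC-3 cells (Homo sapiens) for cytotoxicity, read by MTT assay, with a stated time of 72 h (on this read-out lower numbers stand for stronger inhibition and higher numbers for weaker inhibition), compound 1 gives the lowest of the three numbers. Compound 3 lies within the scatter of compound 1, so no order between them can be claimed, whereas the step of a 3.4-fold higher number from compound 1 to compound 2 (0.54 log units; beyond the scatter) lies beyond the scatter. Compound 4, `CCOC(=O)c1ccc(NC2=CC(=O)c3ncncc3C2=O)cc1`, differs from compound 1 in one place: ethoxycarbonyl in place of trifluoromethoxy on an aromatic carbon. Going by the values given here, the only measured step at that position is the one from compound 1 to compound 2, where a much larger 4-ethylphenyl entered and the number rose modestly. Ethoxycarbonyl is of similar size to trifluoromethoxy, so compound 4 is expected to sit close to compound 1, with at most a modest rise, a 1.4-fold higher number from compound 1 to compound 4 (0.16 log units; within the scatter). Compound 4 is therefore estimated at 1300 nM, within 500 nM to 3500 nM.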

Compound 4, half-maximal inhibitory concentration: 5900 nM
Compound 4: the middle estimate sits 4.5-fold (0.66 log units) below what was measured; the measured number lies above the stated range.
By their numbers in this assay, from the lowest: compounds 1, 3, 2 and 4 (each within the scatter of the next, the first and the last beyond it).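

In this assay, the same count of heavy atoms does not keep the number at this position: ethoxycarbonyl in place of trifluoromethoxy gives a 6.6-fold higher number from compound 1 to compound 4 (0.82 log units; beyond the scatter). Ethoxycarbonyl and the much larger 4-ethylphenyl cannot be told apart, at a 1.9-fold higher number from compound 2 to compound 4 (0.28 log units; within the scatter), so among these three groups only trifluoromethoxy holds the lower number. Nothing available here explains why the number rose with ethoxycarbonyl.

Going by these compounds, whether an amine, a carboxylic acid or the shorter methoxycarbonyl at this position would give a number like that of compound 1 or that of compound 4 remains open. Also open, on these data alone, is whether the rise follows the carbonyl or the ethyl part of the ester.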